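Changing the Group on the Ring Nitrogen of Compound 2

The source may report more compounds than this note shows. Statements on the series, on what has been measured and on what is new or still open speak of the compounds shown alone.

Of the compounds shown here, three built on one shared core have been measured in a functional assay on U-937 cells (Homo sapiens) for cytotoxicity, read by MTT assay, with a stated time of 3 days; a lower number here means a stronger inhibitor, a higher number a weaker inhibitor. Compound 1 `N#Cc1c(NN)nc(SCc2nc3ccccc3[nH]2)nc1-c1ccccc1` gives 3.9 nM. Compound 2 `N#Cc1c(Nc2ccccc2)nc(SCc2nc3ccccc3[nH]2)nc1-c1ccccc1` gives 3.28 nM, and compound 3 `CCNc1nc(SCc2nc3ccccc3[nH]2)nc(-c2ccccc2)c1C#N` gives 2.63 nM. Compound 2 stands second highest of the three numbers, yet every step among them lies within the scatter: a 1.2-fold lower number from compound 1 to compound 2 (0.08 log units; within the scatter), a 1.5-fold lower number from compound 1 to compound 3 (0.17 log units; within the scatter) and a 1.2-fold lower number from compound 2 to compound 3 (0.10 log units; within the scatter). Each of these steps swaps the group on a nitrogen on an aromatic ring, and each time the number stayed within the scatter.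

Compound 4 `N#Cc1c(NC(N)=S)nc(SCc2nc3ccccc3[nH]2)nc1-c1ccccc1` has not yet been measured. It differs from compound 2 at that same nitrogen: a group of 3 heavy atoms (1 carbon, 1 nitrogen, 1 sulfur; no ring) in place of a group of 6 heavy atoms (6 carbon; one six-membered aromatic ring of carbon only), on a nitrogen on an aromatic ring. For the measured compounds named here, no measured step puts this entering group in place, so the only guide is that three swaps at this nitrogen all stayed within the scatter. The expected step from compound 2 to compound 4 is therefore a 1.1-fold higher number from compound 2 to compound 4 (0.03 log units; within the scatter), nothing beyond the scatter. Compound 4 is estimated at 3.5 nM, with a range from 1.5 nM to 9 nM.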

Compound 4, half-maximal inhibitory concentration: 20 nM
For compound 4 the middle estimate is 5.7-fold (0.76 log units) below the measured one; the measured number lies above the stated range.
By their numbers in this assay, from the lowest: compounds 3, 2 and 1 (each within the scatter of the next); then compound 4.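

This nitrogen on an aromatic ring tolerates less than the first three compounds suggested. With the group of 3 heavy atoms (1 carbon, 1 nitrogen, 1 sulfur; no ring) in place, this assay shows a 6.1-fold higher number from compound 2 to compound 4 (0.79 log units; beyond the scatter), a 7.6-fold higher number from compound 3 to compound 4 (0.88 log units; beyond the scatter) and a 5.1-fold higher number from compound 1 to compound 4 (0.71 log units; beyond the scatter), so amino, phenyl and ethyl remain within the scatter of each other while this group alone moves the number clearly upward. Nothing available here accounts for that rise.

The compounds shown leave open whether the sulfur itself matters or the whole group does, and the same group with oxygen in place of sulfur would separate the two. A butyl chain or an acetyl group on this nitrogen would show whether other groups also raise the number.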